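The compounds below may be only part of what the source reports. "The series", "measured", "known", "first", "only" and "open" are said of these compounds alone.

Compound 1 `COCC(=O)NC1CCN(c2nc(C)c3cc(NC(=O)/C=C/c4ccc(OC(F)(F)F)cc4)ccc3n2)CC1` is the reference point for this comparison. In an ADME assay on microsomes from liver (Mus musculus) for metabolic stability, with a stated time of 30 min (on this read-out lower numbers stand for a less stable compound and higher numbers for a more stable compound), compound 1 gives 57%, the second highest of the three numbers recorded. Compound 2 `Cc1nc(NCCCNS(C)(=O)=O)nc2ccc(NC(=O)/C=C/c3ccc(OC(F)(F)F)cc3)cc12` is its closest neighbour: in this assay compound 2 gives 58%, and the step of a number 1 percentage points higher from compound 1 to compound 2 (within the scatter) is within the scatter. Going by the values given here, compound 3 `Cc1nc(N2CCC(O)(C3CCC3)CC2)nc2ccc(NC(=O)/C=C/c3ccc(Cl)cc3)cc12` lies furthest away; in this assay compound 3 gives 12%, a number far lower than that of compound 1, though the two structures differ in more than one place and so no single step connects them.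

Compound 4 `Cc1nc(N2CCC(N3C(=O)CCC3=O)CC2)nc2ccc(NC(=O)/C=C/c3ccc(OC(F)(F)F)cc3)cc12` is not yet measured. It differs from compound 1 in one place: 2,5-dioxopyrrolidin-1-yl in place of ((methoxymethyl)carbonyl)amino on a saturated ring carbon. Among the compounds with values here, the only measured step that touches the same region of the molecule is the one from compound 1 to compound 2, which exchanged the whole group on the aromatic carbon and left the number essentially unchanged. That step is a loose guide at best, since the change to compound 4 keeps the six-membered ring and alters only the group on its saturated carbon. On this basis compound 4 is expected to stay close to compound 1, with a step of a number 2 percentage points lower from compound 1 to compound 4 (within the scatter) that is not beyond the scatter. The estimate for compound 4 in this assay is therefore 55%, with a range from 35% to 75%.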

Compound 4, percent of the compound remaining: 40%
Estimate against measurement, compound 4: 15 percentage points above; low and high end bracket the measured number.
By their numbers in this assay, from the lowest: compound 3; then compound 4; then compounds 1 and 2 (each within the scatter of the next).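

In this assay, the group on the saturated ring carbon, three ring bonds from the ring nitrogen, proves able to move the number on its own: a number 17 percentage points lower from compound 1 to compound 4 (beyond the scatter). This step is beyond the scatter, whereas the broader exchange of the whole group on the aromatic carbon gave only a number 1 percentage points higher from compound 1 to compound 2 (within the scatter), so a change confined to this one carbon can matter more than that larger replacement did. No measurement shown here explains the drop or links it to any property of the entering group.

The change does two things at once, replacing the open ((methoxymethyl)carbonyl)amino group, which has a hydrogen-bond donor, with the five-membered 2,5-dioxopyrrolidin-1-yl ring, which has none, and these compounds cannot tell which of the two goes with the lower number. As far as these compounds go, a pyrrolidin-2-one ring, which keeps a ring but has only one carbonyl, or a simple acetylamino group or free amine on the same carbon would help separate the two, and it also remains open whether the step carries over to the other compounds.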